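Aryl triazene series: cytotoxicity notes, compound 2 to compound 4

The compounds below may be only part of what the source reports. "The series", "measured", "known", "first", "only" and "open" are said of these compounds alone.

Compound 1 `Brc1cccc(/N=N/N2CCCCC2)c1` gives a limit of > 100000 nM in an ADME assay on BHK-21 cells (Mesocricetus auratus) for cytotoxicity, read by MTT assay, with a stated time of 96 h; on this read-out lower numbers stand for higher toxicity in this test and higher numbers for lower toxicity in this test.
Compound 2 `Clc1ccc(/N=N/N2CCCCC2)cc1` gives a limit of > 100000 nM in this assay.
Compound 3 `Cc1ccc(/N=N/c2ccc(NCCCN(C)C)cc2)cc1` gives a limit of > 100000 nM in this assay.

Compound 2 stands at the limit, not at a number, and the two other values are limits as well: all three sit at the limit of > 100000 nM in this assay, at which 3 of the 3 values shown sit. Within the data shown here, no measured step between compounds can be sized from this. Compound 4 `c1ccc(/N=N/N2CCCCC2)cc1` differs from compound 2 by hydrogen in place of chloro on an aromatic carbon. Since every shown value is a limit, the step that the limit leaves unreadable from compound 2 to compound 4 in this assay is expected to be none beyond the scatter. Compound 4 is estimated at 150000 nM, with a range from 60000 nM to 400000 nM, and most likely again reported only as a limit.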

Compound 4, half-maximal cytotoxic concentration: > 100000 nM
Compound 4 was reported as a limit (the forecaster's own chance of this, stated with the estimate: 85%); the middle value is on the limit's open side.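

The steps from compound 1 and from compound 2 to compound 4 cannot be read in this assay, as each value is only a limit: the limit of > 100000 nM in this assay, at which 4 of the 4 values shown sit.

On these data alone, whether hydrogen in place of chloro or bromo on an aromatic carbon shifts the half-maximal cytotoxic concentration at all remains open.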